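Swapping a hydroxyethyl for an isopropyl on a sulfonamide

The compounds below may be only part of what the source reports. "The series", "measured", "known", "first", "only" and "open" are said of these compounds alone.

Measured so far:
- compound 1, `CCC1C(=O)N(C)c2cnc(-n3ccc4cc(C(N)=O)ccc43)nc2N1c1ccn(C)n1`: 27400 nM
- compound 2, `CC[C@@H]1C(=O)N(C)c2cnc(Nc3ccc(S(=O)(=O)NCCO)cc3)nc2N1C1CCCC1`: 459 nM
- compound 3, `CCC1C(=O)N(C)c2cnc(Nc3ccc(S(=O)(=O)NCCCO)cc3)nc2N1c1ccn(C)n1`: 23700 nM

In a functional assay on HeLa cells (Homo sapiens) for antiproliferative activity, read by CCK-8 assay, with a stated time of 72 h (a higher number here means a weaker inhibitor of growth, a lower number a stronger inhibitor of growth), compound 3 gives 23700 nM. That number is the second highest of the three. Compound 1 sits nearest to it, at 27400 nM, and the two lie within the scatter of each other, so no order between them can be claimed. Compound 2, at 459 nM, gives a far lower number than compound 3, and that gap is well beyond the scatter; compound 2 differs from compound 3 in more than one place, so its values only show that much lower numbers are reachable within this family.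

Compound 4, `CCC1C(=O)N(C)c2cnc(Nc3ccc(S(=O)(=O)NCC(C)C)cc3)nc2N1c1ccn(C)n1`, has not yet been measured. It differs from compound 3 in one place: isopropyl in place of 2-hydroxyethyl on a saturated chain carbon bound to a sulfonamide nitrogen. Among the compounds with values here, no measured pair shows what this kind of change does here, so there is no step to lean on. The two measured compounds that share the core of compound 3, compound 1 and compound 3, both give high numbers in this assay despite carrying quite different groups on the other side of the molecule, which suggests the side-chain swap is unlikely to move the number very far.

Compound 4 is therefore expected to land close to compound 3, with a step of a 1.2-fold lower number from compound 3 to compound 4 (0.07 log units; within the scatter) that may well lie within the scatter. The estimate for compound 4 in this assay is 20000 nM, within a range from 6000 nM to 60000 nM.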

Compound 4, concentration for 50% growth inhibition: 5310 nM
The estimate for compound 4 lay 3.8-fold (0.58 log units) above the measured number, and the stated range ends above it.
By their numbers in this assay, from the lowest: compound 2; then compound 4; then compounds 3 and 1 (each within the scatter of the next).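

The swap of 3-hydroxypropyl to isobutyl on the sulfonamide, which also reads as 2-hydroxyethyl to isopropyl on a saturated chain carbon bound to a sulfonamide nitrogen, gives in this assay a 4.5-fold lower number from compound 3 to compound 4 (0.65 log units; beyond the scatter). Within the data shown here, this is the first pair that differs in one place only, and it shows that this side chain can shift the number on its own, even though the group that enters has the same count of heavy atoms as the one that leaves and differs in holding only carbon, with no hydrogen-bond donor or acceptor. The data at hand give no measurement that would explain why the number falls with this change.

This single pair cannot separate losing the hydroxyl from branching the chain, so an unbranched propyl group would be needed to tell those two apart, while a terminal amine, a carboxylic acid or a longer alkyl chain at this place remains unexplored among the compounds shown. From the compounds shown here alone, whether the same swap has a similar effect in compound 2, which differs from compound 3 in more than one place, also stays open.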